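The source may report more compounds than this note shows. Statements on the series, on what has been measured and on what is new or still open speak of the compounds shown alone.

Compound 1 `Nc1nc(Nc2ccccc2)sc1C(=O)c1cccc(F)c1`: 4100 nM
Compound 2 `Nc1nc(Nc2ccc(S(N)(=O)=O)cc2)sc1C(=O)c1cccc(F)c1`: 3900 nM

In a functional assay on GC-2 cells (Mus musculus) for cytotoxicity, read by MTT assay, with a stated time of 72 h (a lower number here means a stronger inhibitor, a higher number a weaker inhibitor), compound 2 gives 3900 nM, level with compound 1 within the usual scatter. Compound 3 `COc1cccc(C(=O)c2sc(Nc3ccc(S(N)(=O)=O)cc3)nc2N)c1` differs from compound 2 in one place: methoxy in place of fluoro on an aromatic carbon. Methoxy stands in place of fluoro on an aromatic carbon, meta to a large group. Among the compounds with values here, the only measured step, a 1.1-fold lower number from compound 1 to compound 2 (0.02 log units; within the scatter), changed a different place, so it says nothing direct about this swap. Within the data shown here, no measured step shows a direction, so the expectation stays with compound 2 at 3900 nM, with no shift beyond the scatter. The expected step is a 1.1-fold lower number from compound 2 to compound 3 (0.05 log units; within the scatter). Compound 3 is estimated at 3500 nM, with an expected range of 1200 nM to 10000 nM.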

Compound 3, half-maximal inhibitory concentration: 11000 nM
Estimate against measurement, compound 3: 3.1-fold (0.50 log units) below; the whole stated range lies below it.
By their numbers in this assay, from the lowest: compounds 2 and 1 (each within the scatter of the next); then compound 3.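

In this assay, within the data shown here, going from 3-fluorophenyl to 3-methoxyphenyl gives a 2.8-fold higher number from compound 2 to compound 3 (0.45 log units; beyond the scatter) and is the first step here beyond the scatter. This position therefore responds to what is placed on it, and methoxy gives a weaker result than fluoro, while the earlier sulfamoyl step at another place stayed within the scatter. No available evidence explains the change. Going by these compounds, whether a chloro, methyl or hydroxyl group at this place would behave like fluoro or like methoxy remains open. So does whether the same swap would shift compound 1 by a similar step.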